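The source may hold more compounds than are shown below. What is called first, only, known or untested is meant among the compounds shown, and "the series" means these compounds.

Compound 1 `CCC[C@]1(c2ccccc2)OC[C@H]([C@@H]2CCCCN2)O1` and compound 2 `CCCC[C@]1(c2ccccc2)OC[C@H]([C@@H]2CCCCN2)O1` share a core; in a functional assay (brain) for displacement of a labelled ligand, with Rattus norvegicus as the target (a higher number here means a weaker inhibitor, a lower number a stronger inhibitor), compound 1 gives 69 nM and compound 2 gives 200 nM, so a 2.9-fold higher number from compound 1 to compound 2 (0.46 log units; beyond the scatter) for the change (methyl in place of hydrogen on a saturated chain carbon, three bonds along the chain from a saturated ring carbon). Compound 3 `NC[C@H]1COC(c2ccccc2)(c2ccccc2)O1` has a different core, and the difference between the two cores is not broken down here; in this assay compound 3 gives 1400 nM. Compound 4 `C[C@H](N)[C@H]1COC(c2ccccc2)(c2ccccc2)O1` is the unmeasured one, and the change methyl in place of hydrogen on a saturated chain carbon bound to an amine nitrogen and a saturated ring carbon is the same kind of change as the earlier one, though here the place is bound to an amine nitrogen and a saturated ring carbon rather than three bonds along the chain from a saturated ring carbon. Because the earlier methyl gave a 2.9-fold higher number from compound 1 to compound 2 (0.46 log units; beyond the scatter), a similar weakening is expected, giving a 2.0-fold higher number from compound 3 to compound 4 (0.30 log units; within the scatter). Compound 4 is therefore estimated at 2800 nM, within 900 nM to 8000 nM.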

Compound 4, inhibition constant: 607 nM
Beside the measured number, compound 4's estimate is 4.6-fold (0.66 log units) above it, and the stated range ends above it.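

In this assay, a methyl in place of hydrogen on a saturated chain carbon bound to an amine nitrogen and a saturated ring carbon gives a 2.3-fold lower number from compound 3 to compound 4 (0.36 log units; beyond the scatter), so here the added methyl goes with a stronger inhibitor. The same kind of change therefore does not carry over in direction from one core to the other: the same change on two cores in this assay, a 2.9-fold higher number (0.46 log units; beyond the scatter) from compound 1 to compound 2 and a 2.3-fold lower number (0.36 log units; beyond the scatter) from compound 3 to compound 4, 6.7-fold (0.83 log units) apart, beyond the scatter of two such steps This does not show whether the core or the place of the methyl sets the direction, since the two steps differ in both and each rests on a single pair.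

As far as these compounds go, it remains open whether an ethyl at the place of the new methyl would go further in the same direction. From the compounds shown here alone, it is also open how a methyl at that same place would act on the core of compound 1.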